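Solubility notes on the pyrazole amide series, compound 4

A few compounds are considered here, and "the series" means these few. Any claim that something is new, unique, unknown or untested is made for them only; others in the source may bear on it.

Measured so far:
- compound 1, `CC1(C)c2[nH]nc(NC(=O)c3ccc(F)cc3)c2CN1C(=O)C1CCN(C2CC2)CC1`: > 225000 nM
- compound 2, `CC(=O)N1CCN(C(=O)N2Cc3c(NC(=O)c4ccc(F)cc4)n[nH]c3C2(C)C)CC1`: > 225000 nM
- compound 3, `CN1CCC(C(=O)N2Cc3c(NC(=O)c4cccs4)n[nH]c3C2(C)C)CC1`: 155000 nM

In a physicochemical assay for solubility, at pH 7 (on this read-out higher numbers stand for higher solubility and lower numbers for lower solubility), compound 1 reaches only a limit of the assay, > 225000 nM. In this assay compound 2 likewise gives a limit, > 225000 nM, and not a number. Compound 3 gives a number in this assay, 155000 nM. Within the data shown here, the one step among measured compounds, a step that the two limits leave unreadable from compound 1 to compound 2, cannot be sized, since both ends are limits; what holds it together is the limit of > 225000 nM in this assay, at which 2 of the 3 values shown sit.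

Compound 4, `CC(=O)N1CCC(C(=O)N2Cc3c(NC(=O)c4ccc(F)cc4)n[nH]c3C2(C)C)CC1`, is not yet measured. It differs from compound 2 by 1-acetylpiperidin-4-yl in place of 4-acetylpiperazin-1-yl on a carbonyl carbon. No measured step bears on this change: the only step shown, from compound 1 to compound 2, is unreadable, and compound 3 differs from both in two places and so gives no step. The starting point, compound 2, stands at the limit, and compound 3 with its different acetyl-free ring still sits within the scatter of that limit. Compound 4 is therefore expected to stay at or near the ceiling of this assay, with an at least 1.1-fold lower number from compound 2 to compound 4 (0.05 log units; that floor lies within the scatter) read as no step beyond the scatter. The estimate for compound 4 is 200000 nM, between 100000 nM and 400000 nM, with a fair chance that only a limit is reported.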

Compound 4, solubility: 204000 nM
Compound 4: the middle estimate sits 1.0-fold (0.01 log units) below what was measured; low and high end bracket the measured number.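

In this assay compound 4 gives a number, 204000 nM. With 1-acetylpiperidin-4-yl in place of 4-acetylpiperazin-1-yl on a carbonyl carbon the result is an at least 1.1-fold lower number from compound 2 to compound 4 (0.04 log units; that floor lies within the scatter), and with acetyl in place of cyclopropyl on an amine nitrogen in a ring it is an at least 1.1-fold lower number from compound 1 to compound 4 (0.04 log units; that floor lies within the scatter); each is only a floor, and neither shows a step beyond the scatter. Neither step can be sized further, since the upper end of each is a limit of the assay and not a number: the limit of > 225000 nM in this assay, at which 2 of the 4 values shown sit.

The compounds shown leave open what a morpholin-4-yl group, or a longer chain ending in a carboxylic acid, would give on that same carbonyl carbon. Among these compounds, compound 3 differs from compound 4 in two places, so it gives no step and the acetyl group on the ring nitrogen remains untested against a single change from the methyl group of compound 3.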